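Amide to ester on a CDK8 inhibitor: an expected loss

The compounds below may be only part of what the source reports. "The series", "measured", "known", "first", "only" and "open" are said of these compounds alone.

Compound 1 `CNC(=O)/C=C/c1ccncc1-c1ccc2ccccc2c1` is measured in an assay on a protein complex for inhibition of CDK8/Cyclin C (Homo sapiens), with a stated time of 1 h (a lower number here means a stronger inhibitor, a higher number a weaker inhibitor), where compound 1 gives 12.4 nM. Of the two values known, this is the lower; compound 2 `Cn1ncc2cc(-c3cnccc3/C=C/C(=O)O)ccc21` gives 34.6 nM in this assay, a gap beyond the usual scatter. Compound 3 `COC(=O)/C=C/c1ccncc1-c1ccc2ccccc2c1` differs from compound 1 in one place: methoxy in place of methylamino on a carbonyl carbon. The methylamino that leaves carries the only hydrogen-bond donor of that group; the methoxy that enters carries none. Going by the values given here, with no measured pair of this kind to lean on, the step from compound 1 to compound 3 is expected to weaken inhibition moderately, as a 3.2-fold higher number from compound 1 to compound 3 (0.51 log units; beyond the scatter). Compound 3 is therefore estimated at 40 nM, within 10 nM to 160 nM.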

Compound 3, half-maximal inhibitory concentration: 40.6 nM
The estimate for compound 3 lay 1.0-fold (0.01 log units) below the measured number, and the stated range covers the measured number.
By their numbers in this assay, from the lowest: compound 1; then compounds 2 and 3 (each within the scatter of the next).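

Placing methoxy on the carbonyl carbon in place of methylamino gives a 3.3-fold higher number from compound 1 to compound 3 (0.52 log units; beyond the scatter) in this assay, the first measured step at this place, and it lies beyond the scatter. The change removes the amide hydrogen and weakens inhibition without abolishing it. Nothing available here explains why the number rises. Still open, on these data alone, is how a dimethylamino or ethylamino group would fare on the carbonyl carbon of the core of compound 1, and whether keeping a nitrogen there matters more than keeping the amide hydrogen.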